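Compound 3 to Compound 4: Flipping One Stereocentre

A few compounds are considered here, and "the series" means these few. Any claim that something is new, unique, unknown or untested is made for them only; others in the source may bear on it.

Measured so far:
- Compound 1 `CCc1cccc(NC(=O)N[C@@H](C)c2ccccc2)c1`: in an ADME assay on the whole organism with Oryza sativa as the target, tested at 1 uM (on this read-out higher numbers stand for a weaker effect at the one concentration tested and lower numbers for a stronger effect), compound 1 gives 94%
- Compound 2 `COc1cccc(NC(=O)N[C@@H](C)c2ccccc2)c1`: in this assay compound 2 gives 99%
- Compound 3 `C[C@@H](NC(=O)Nc1cccc(Cl)c1)c1ccccc1`: in this assay compound 3 gives 91%

All three compounds share one core and differ only in the group on the aromatic ring or in configuration. Among the compounds with values here, the only step between measured compounds that differ in one place runs a number 5 percentage points higher from compound 1 to compound 2 (within the scatter). Within the data shown here, on the numbers so far, compound 3 gives the lowest value of the three, but its gaps to compound 1 and to compound 2 both fall within the usual scatter, so none of the three can be called stronger or weaker than another.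

Compound 4 `C[C@H](NC(=O)Nc1cccc(Cl)c1)c1ccccc1` has not yet been measured in this assay. Its difference from compound 3 is the two compounds have the same atoms and bonds and differ only in configuration as drawn: 1 of 1 stereo elements differ; a stereocentre at a saturated chain carbon is drawn R in compound 3 and S in compound 4. Among the measured compounds shown here, no measured step involves a change of configuration: the one step known, between compound 1 and compound 2, swaps a group on the aromatic ring and does not bear on this change. With nothing to point in either direction, no step beyond the scatter is expected. The estimate for compound 4 is therefore 91%, with a range from 78% to 100%, which would mean an expected step of no change at the digits printed from compound 3 to compound 4 (within the scatter).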

Compound 4, a percentage reported as activity, at one concentration (the size of the read-out at that concentration, not a potency): 99%
For compound 4 the middle estimate is 8 percentage points below the measured one; the range from low to high includes it.
By their numbers in this assay, from the lowest: compounds 3, 1, 2 and 4 (each within the scatter of the next).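

Within the data shown here, compound 4 gives the first reading on configuration at the saturated chain carbon: in this assay the step is a number 8 percentage points higher from compound 3 to compound 4 (within the scatter) and so does not separate the R drawing from the S drawing. It also adds two readings on the group at the aromatic carbon, where chloro in place of methoxy gives no change at the digits printed from compound 2 to compound 4 (within the scatter) and chloro in place of ethyl gives a number 5 percentage points higher from compound 1 to compound 4 (within the scatter), so none of these three groups stands apart from another here. The comparison of the stereoisomers is a clean one, with no second change to account for: the fact that compounds 3 and 4 differ only in the configuration as drawn.

From the compounds shown here alone, whether configuration would count for more with an amine or a carboxylic acid on the aromatic carbon remains open, as does the reading for a longer chain in that place. Also open is whether any change to the shared core can move this read-out beyond the usual scatter, since every step among these four compounds stays within it.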